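The compounds below may be only part of what the source reports. "The series", "measured", "known", "first", "only" and "open" are said of these compounds alone.

Three esters of the shared core carry numbers in a functional assay on HepG2 cells (Homo sapiens) for inhibition, read by MTT assay, with a stated time of 72 h; a higher number here means a weaker inhibitor, a lower number a stronger inhibitor. Compound 1 `O=C(OC1(C(=O)Nc2ccc([N+](=O)[O-])cc2)CCCCC1)c1ccc(Cl)cc1` gives 21.8 nM. Compound 2 `CCOC(=O)c1ccccc1C(=O)OC1(C(=O)Nc2ccc([N+](=O)[O-])cc2)CCCCC1` gives 517 nM, and compound 3 `O=C(OC1(C(=O)Nc2ccc([N+](=O)[O-])cc2)CCCCC1)c1ccccc1` gives 734 nM. On these numbers compound 2 stands second highest of the three: compound 3 is its nearest neighbour and the two lie within the scatter of each other, while compound 1 sits far lower, beyond the scatter.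

Compound 4 `CC(=O)Oc1ccccc1C(=O)OC1(C(=O)Nc2ccc([N+](=O)[O-])cc2)CCCCC1` is not yet measured. It differs from compound 2 by acetoxy in place of ethoxycarbonyl on an aromatic carbon. Among the compounds with values here, the only measured step that concerns the ethoxycarbonyl, a 1.4-fold higher number from compound 2 to compound 3 (0.15 log units; within the scatter), shows that taking this group away altogether leaves the number within the scatter. The large step of a 34-fold higher number from compound 1 to compound 3 (1.53 log units; beyond the scatter) concerns a chloro group, not the ethoxycarbonyl, and does not speak to the present exchange. A step no larger than the scatter is therefore expected in this assay. For compound 4 the estimate is 600 nM, with a range from 250 nM to 1500 nM. The expected step this implies, a 1.2-fold higher number from compound 2 to compound 4 (0.06 log units; within the scatter), lies within the scatter.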

Compound 4, half-maximal inhibitory concentration: 17.7 nM
Compound 4: middle estimate off by 34-fold (1.53 log units), on the high side, and the stated range ends above it.
By their numbers in this assay, from the lowest: compounds 4 and 1 (each within the scatter of the next); then compounds 2 and 3 (each within the scatter of the next).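

In this assay, the aromatic carbon ortho to a large group is not indifferent to what it carries, as the exchange of ethoxycarbonyl for acetoxy gives a 29-fold lower number from compound 2 to compound 4 (1.47 log units; beyond the scatter) and the exchange of hydrogen for acetoxy gives a 41-fold lower number from compound 3 to compound 4 (1.62 log units; beyond the scatter) even though the ethoxycarbonyl and hydrogen forms differ only by a 1.4-fold higher number from compound 2 to compound 3 (0.15 log units; within the scatter) within the scatter. The ester's aryl group also has more than one form that reaches the low end of the series, since 2-acetoxyphenyl in place of 4-chlorophenyl gives only a 1.2-fold lower number from compound 1 to compound 4 (0.09 log units; within the scatter) and the two cannot be told apart. Nothing at hand accounts for the gap between acetoxy and ethoxycarbonyl at this carbon.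

Going by these compounds, whether the low number needs the whole acetoxy group remains open, and a hydroxy group, a methoxy group or a longer acyloxy chain at the same carbon would test this. Also open, on these data alone, is whether acetoxy and chloro on the same aryl ring would add together.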